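The source may report more compounds than this note shows. Statements on the series, on what has been measured and on what is new or still open speak of the compounds shown alone.

In a physicochemical assay for lipophilicity, read by HPLC, with a stated time of 90 min, tested at 100 uM (a higher number here means a more lipophilic compound, a lower number a more polar compound), compound 1 (`O=C(Nc1ccc(C(F)(F)F)cc1)NC1CCN(C(=O)C2CCCOC2)CC1`) gives 3.41 as the lowest of three measured numbers. Compound 2 (`CC(C)C(=O)N1CCC(NC(=O)Nc2ccc(C(F)(F)F)c(F)c2)CC1`) stands nearest at 4.4 and compound 3 (`CC(C)C(=O)N1CCC(CC(=O)Nc2ccc(OC(F)(F)F)c(F)c2)CC1`) furthest at 5.81 with both gaps from compound 1 beyond the usual scatter. Compound 4 (`O=C(Nc1ccc(C(F)(F)F)cc1)NC1CCN(C(=O)c2cc[nH]c2)CC1`) is still unmeasured and carries 1H-pyrrol-3-yl in place of oxan-3-yl on a carbonyl carbon. For the measured compounds named here, no measured pair of compounds isolates this change, so the expectation rests on the structural change alone. In this assay the expected step is small and upward, staying within the scatter (a number 0.19 log units higher from compound 1 to compound 4 (within the scatter)). For compound 4 the estimated value is 3.6 with an expected range from 3.1 to 4.1 on this scale.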

Compound 4, partition coefficient: 3.26
The estimate for compound 4 lay 0.34 log units above the measured number; the range from low to high includes it.
By their numbers in this assay, from the lowest: compounds 4 and 1 (each within the scatter of the next); then compound 2; then compound 3.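

For the compounds shown here, this is the first pair here that differs in one place only: in this assay, 1H-pyrrol-3-yl in place of oxan-3-yl on a carbonyl carbon gives a number 0.15 log units lower from compound 1 to compound 4 (within the scatter). At this place, then, a six-membered non-aromatic ring and a five-membered aromatic ring with a hydrogen-bond donor give numbers that cannot be told apart. No measurement is available to explain this result. Still open, going by these compounds, is whether a ring carrying an amine or a carboxylic acid, or a longer chain, at this place would shift the number beyond the scatter.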